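A few compounds are considered here, and "the series" means these few. Any claim that something is new, unique, unknown or untested is made for them only; others in the source may bear on it.

Measured so far: compound 1 `CNCC(=O)Nc1cc(OC)ccc1C(=O)c1ccc(OC)c2c1OC(C)(C)C=C2` gives 820 nM; compound 2 `COc1ccc(C(=O)c2ccc(OC)c3c2OC(C)(C)C=C3)c(NC(=O)CN(C)C)c1` gives 2680 nM; compound 3 `C=C(c1ccc(OC)cc1NC(=O)CN)c1ccc(OC)c2c1OC(C)(C)C=C2` gives 220 nM, all in a functional assay on MCF7 cells (Homo sapiens) for antiproliferative activity, read by MTT assay, with a stated time of 48 h; a lower number here means a stronger inhibitor, a higher number a weaker inhibitor.

Compound 2 differs from compound 1 by methyl in place of hydrogen on an amine nitrogen, and this change gave a 3.3-fold higher number from compound 1 to compound 2 (0.51 log units; beyond the scatter). Compound 3 stands lowest of the three numbers, and its core is not the core of compound 1: the difference between the two cores is not broken down here. Compound 4 `C=C(c1ccc(OC)cc1NC(=O)CNC)c1ccc(OC)c2c1OC(C)(C)C=C2` has not yet been measured in this assay. It differs from compound 3 by methyl in place of hydrogen on an amine nitrogen. This is the same kind of change as that from compound 1 to compound 2, but not the same: in compound 1 the amine nitrogen has two saturated chain carbons as its other neighbours, in compound 3 only one. Because the earlier step gave a 3.3-fold higher number from compound 1 to compound 2 (0.51 log units; beyond the scatter), compound 4 is expected to give a somewhat higher number than compound 3, an expected step of a 2.0-fold higher number from compound 3 to compound 4 (0.31 log units; beyond the scatter). Compound 4 is therefore estimated at 450 nM, most likely between 180 nM and 1200 nM.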

Compound 4, half-maximal inhibitory concentration: 400 nM
The estimate for compound 4 lay 1.1-fold (0.05 log units) above the measured number, within the range that was stated.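

In this assay, methyl in place of hydrogen on the amine nitrogen gave a 1.8-fold higher number from compound 3 to compound 4 (0.26 log units; within the scatter), so on the core of compound 3 the step cannot be told apart from the spread of repeated measurements. Set beside the earlier step, it does not differ from it by more than such spread allows: the same change on two cores in this assay, a 3.3-fold higher number (0.51 log units; beyond the scatter) from compound 1 to compound 2 and a 1.8-fold higher number (0.26 log units; within the scatter) from compound 3 to compound 4, 1.8-fold (0.25 log units) apart, within the scatter of two such steps. This shows that the change can be carried between these two cores without a detectable difference in the size of its step, but it does not show that the step is the same, since each core offers a single pair and the nitrogen of compound 1 already carries a methyl, whereas that of compound 3 does not.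

The compounds shown leave open how a dimethylamino group would read on the core of compound 3, and an amino group on the core of compound 1. They also leave open what an ethyl group, a longer chain or a cyclic amine such as morpholine would do on this nitrogen.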